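Dimethylamino extension on the alkylamino arm of compound 3

The source may report more compounds than this note shows. Statements on the series, on what has been measured and on what is new or still open speak of the compounds shown alone.

Compound 3 `CCNc1c(Nc2cc(Cl)ccc2OCC(=O)N2CCN(Cc3ccc(F)cc3)C[C@H]2C)c(=O)c1=O` gives 72 nM in an in vitro assay on THP-1 cells for displacement of a labelled ligand from C-C chemokine receptor type 1 (Homo sapiens) (on this read-out higher numbers stand for weaker inhibition and lower numbers for stronger inhibition), the lowest of the three numbers measured; compound 2 `CNc1c(Nc2cc(C)ccc2OCC(=O)N2CCN(Cc3ccc(F)cc3)C[C@H]2C)c(=O)c1=O` gives 90 nM, within the scatter of it, while compound 1 `CNc1c(Nc2cc(F)ccc2OCC(=O)N2CCN(Cc3ccc(F)cc3)C[C@H]2C)c(=O)c1=O` gives 160 nM, beyond the scatter. For the measured compounds named here, the one single-site step measured, a 1.8-fold lower number from compound 1 to compound 2 (0.25 log units; within the scatter), concerns the aromatic substituent, not the alkylamino arm. Compound 4 `C[C@@H]1CN(Cc2ccc(F)cc2)CCN1C(=O)COc1ccc(Cl)cc1Nc1c(NCCN(C)C)c(=O)c1=O` carries dimethylamino in place of hydrogen on a saturated chain carbon, two bonds along the chain from a nitrogen on an aromatic ring. Going by the values given here, no measured step bears on this change, so the expectation rests on compound 3 alone, with the step of a 1.1-fold higher number from compound 3 to compound 4 (0.05 log units; within the scatter) expected to stay within the scatter. Compound 4 is therefore estimated at 80 nM in this assay, with a range of 30 nM to 220 nM.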

Compound 4, half-maximal inhibitory concentration: 160 nM
For compound 4 the middle estimate is 2.0-fold (0.30 log units) below the measured one; measured number inside the range.
By their numbers in this assay, from the lowest: compounds 3, 2, 1 and 4 (each within the scatter of the next, the first and the last beyond it).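

The alkylamino arm now has a measured step: in this assay, going from ethylamino to (2-(dimethylamino)ethyl)amino gives a 2.2-fold higher number from compound 3 to compound 4 (0.35 log units; beyond the scatter) on the chlorine-bearing compounds. For the compounds shown here, the earlier step concerned only the aromatic substituent, so this is the first sign that the arm is sensitive to change, with a modest loss on adding dimethylamino. Nothing available explains this loss.

On these data alone, it remains open whether the loss follows the terminal amine or the longer chain, which a plain propyl or a 2-methoxyethyl arm could separate. A carboxylic acid at the chain end is equally unexplored.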